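The compounds below may be only part of what the source reports. "The series", "measured", "known", "first", "only" and "open" are said of these compounds alone.

Working notes on the series. The read-out throughout is a functional assay on HepG2 cells (Homo sapiens) for cytotoxicity, read by MTT assay, with a stated time of 72 h; a lower number here means that less compound is tolerated, a higher number that more compound is tolerated. Compound 1, with structure `C[Se]/C(=N\C(=O)c1cc2ccccc2s1)NC(=O)c1cc2ccccc2s1`, gives 73300 nM in this assay. Compound 2, with structure `CS/C(=N\C(=O)c1csc([N+](=O)[O-])c1)NC(=O)c1csc([N+](=O)[O-])c1`, gives only a limit of the assay in this assay, at > 100000 nM. Compound 3, with structure `C[Se]/C(=N\C(=O)c1ccco1)NC(=O)c1ccco1`, likewise gives only a limit in this assay, at > 100000 nM. Among the measured compounds shown here, the only number among the three therefore belongs to compound 1; for compound 3 nothing beyond the limit is known, and the limit of > 100000 nM in this assay, at which 2 of the 3 values shown sit, marks where it sits together with compound 2.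

Compound 4, with structure `CS/C(=N\C(=O)c1ccco1)NC(=O)c1ccco1`, has not yet been measured in this assay. It differs from compound 3 by a group of 2 heavy atoms (1 carbon, 1 sulfur; no ring) in place of a group of 2 heavy atoms (1 carbon, 1 selenium; no ring), on a carbon with a double bond to nitrogen, in words a group of 2 heavy atoms (1 carbon, 1 sulfur; no ring) in place of a group of 2 heavy atoms (1 carbon, 1 selenium; no ring), on a carbon with a double bond to nitrogen. For the measured compounds named here, no measured pair shares this change, so its size cannot be read from a step. The expectation is a step from compound 3 to compound 4 of no size beyond the scatter, as a number no higher from compound 3 to compound 4 (the limit leaves the size open), and most probably a further limit. Compound 4 is estimated in this assay at 100000 nM, within a range from 50000 nM to 200000 nM.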

Compound 4, concentration lethal to 50% of the cells: > 100000 nM
Compound 4 gave a limit, no number; the forecaster's own chance of this, stated with the estimate: 65%; the middle value sits exactly at the limit.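

Compound 3 and compound 4 each give only a limit in this assay, so no step can be read between them for methylsulfanyl in place of the selenium-carrying group. The compounds shown leave open whether this exchange alters the tolerated concentration at all, as the read-out for most of them rests on one limit: the limit of > 100000 nM in this assay, at which 3 of the 4 values shown sit.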